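The compounds below may be only part of what the source reports. "The series", "measured", "known", "first", "only" and "open" are said of these compounds alone.

Measured in an ADME assay on HeLa cells (Homo sapiens) for cytotoxicity, read by crystal violet staining, with a stated time of 72 h; on this read-out lower numbers stand for higher toxicity in this test and higher numbers for lower toxicity in this test:
- compound 1 `CN(C)C(=O)c1cc(CCCOc2ccc(-c3noc(C(F)(F)F)n3)cc2)on1`: 28000 nM
- compound 2 `CCOC(=O)c1cc(CCCOc2ccc(-c3noc(C(F)(F)F)n3)cc2NC(C)=O)on1`: > 100000 nM (a limit)

Compound 2 reads > 100000 nM, which is a limit of this assay and not a number. Its position is also described by the limit of > 100000 nM in this assay, at which 1 of the 2 values shown sits. Going by the values given here, compound 1 and compound 2 differ in more than one place, so the series has no measured single-change step to draw on.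

The next compound is compound 3 `CC(=O)Nc1cc(-c2noc(C(F)(F)F)n2)ccc1OCCCc1cc(C(=O)N(C)C)no1`, where dimethylamino stands in place of ethoxy on a carbonyl carbon: dimethylamino in place of ethoxy on a carbonyl carbon. Among the compounds with values here, the only reading for a compound with the dimethylcarbamoyl group is that of compound 1, at 28000 nM, and this sets the lower side of the expectation. The other difference between compound 1 and compound 2 is kept in compound 3, so a return to the value of compound 1 is not the central expectation. A modest move toward lower numbers in this assay is expected, and a reading that stays at the limit remains quite possible. The expected step is an at least 1.2-fold lower number from compound 2 to compound 3 (0.09 log units; that floor lies within the scatter). For compound 3 the estimated value is 80000 nM, with an expected range from 35000 nM to 130000 nM.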

Compound 3, half-maximal cytotoxic concentration: > 100000 nM
Compound 3 was reported as a limit; the forecaster's own chance of this, stated with the estimate: 45%; at least 1.2-fold (0.09 log units) between middle value and limit.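

In this assay the series now has its first single-change step, acetamido in place of hydrogen on an aromatic carbon with the dimethylcarbamoyl group held fixed: an at least 3.5-fold higher number from compound 1 to compound 3 (0.55 log units; beyond the scatter). On these data alone, compound 3 gives > 100000 nM, which is a limit of the assay and not a number, so this step gives only a minimum size and the full size of the change stays unknown. The change from ethoxy to dimethylamino on a carbonyl carbon cannot be read, because compound 2 and compound 3 both carry limits: the limit of > 100000 nM in this assay, at which 2 of the 3 values shown sit.

As far as these compounds go, it remains open whether ethoxy and dimethylamino differ at all in this assay when acetamido is present, and how the two compare on the core of compound 1 without acetamido. An amine or a carboxylic acid in place of acetamido on the same aromatic carbon would test whether the higher number in this assay is specific to acetamido or also appears with other groups at that place.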